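This account rests on a few compounds, and the source may have more. Where it says the series, first, only, none or still open, it means among the compounds named here.

Compound 1 `CCCOC(=O)/C=C/c1ccc(NC(=O)C2(NC(=O)c3ccc4c(C5CCCC5)c(-c5ncc(Cl)cn5)n(C)c4c3)CCC2)cc1OCC` is one of three compounds tested in an ADME assay (liver) for pharmacokinetics, with Liver microsome (Rattus norvegicus) as the target, using microsomes (on this read-out lower numbers stand for a shorter-lived compound and higher numbers for a longer-lived compound), where compound 1 gives 0.35 h. Among these three numbers compound 1 holds the second highest. Its nearest neighbour is compound 3 `CCCN(C)C(=O)COC(=O)/C=C/c1ccc(NC(=O)C2(NC(=O)c3ccc4c(C5CCCC5)c(-c5ncc(Cl)cn5)n(C)c4c3)CCC2)cc1OCC`, which in this assay gives 0.317 h; the two values lie within the usual scatter of each other. Compound 2 `CCOc1cc(NC(=O)C2(NC(=O)c3ccc4c(C5CCCC5)c(-c5ncc(Cl)cn5)n(C)c4c3)CCC2)ccc1/C=C/C(=O)OCC(=O)OC` gives 2.08 h, and the step of a 5.9-fold higher number from compound 1 to compound 2 (0.77 log units; beyond the scatter) is the widest gap among the measured compounds.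

Compound 4 `CCOc1cc(NC(=O)C2(NC(=O)c3ccc4c(C5CCCC5)c(-c5ncc(Cl)cn5)n(C)c4c3)CCC2)ccc1/C=C/C(=O)OCC(=O)N1CCCC1` has not yet been measured in this assay. It differs from compound 1 in one place: (pyrrolidin-1-yl)carbonyl in place of ethyl on a saturated chain carbon bound to an oxygen next to a carbonyl group.

Two measured steps speak to this change. The step of a 1.1-fold lower number from compound 1 to compound 3 (0.04 log units; within the scatter) puts a carbamoyl group on the same saturated chain carbon and leaves the number essentially where it was. The step of a 6.6-fold lower number from compound 2 to compound 3 (0.82 log units; beyond the scatter) shows that an amino group on the carbonyl carbon, in place of methoxy, brings the number back down to the level of compound 1. Because the step of a 1.1-fold lower number from compound 1 to compound 3 (0.04 log units; within the scatter) is within the scatter, the (pyrrolidin-1-yl)carbonyl group of compound 4 is expected to behave like the carbamoyl group of compound 3, and the expected step is no change at the digits printed from compound 1 to compound 4 (within the scatter), no change beyond the scatter. Compound 4 is therefore estimated to give 0.35 h in this assay, with a likely range from 0.15 h to 0.9 h.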

Compound 4, half-life: 1.47 h
For compound 4 the middle estimate is 4.2-fold (0.62 log units) below the measured one; measured number outside the range, above it.
By their numbers in this assay, from the lowest: compounds 3 and 1 (each within the scatter of the next); then compounds 4 and 2 (each within the scatter of the next).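

In this assay, placing a carbonyl group with an attached nitrogen on this saturated chain carbon does not by itself settle the outcome: a 4.6-fold higher number from compound 3 to compound 4 (0.67 log units; beyond the scatter) shows that two such groups can part ways when pyrrolidin-1-yl replaces methyl(propyl)amino on the carbonyl carbon. For the compounds shown here, the earlier pair of compound 1 and compound 3 alone suggested that this kind of change does little, but a 4.2-fold higher number from compound 1 to compound 4 (0.62 log units; beyond the scatter) goes against that reading, and compound 3 now stands as the one of these carbonyl-bearing compounds that stays level with compound 1. At the same time, a 1.4-fold lower number from compound 2 to compound 4 (0.15 log units; within the scatter) places the pyrrolidin-1-yl compound level with the methoxy compound, and no measurement shown here explains why these groups differ on this read-out.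

The compounds shown leave open whether closing the nitrogen substituents into a ring is what separates compound 4 from compound 3, or whether the particular groups matter instead. A piperidin-1-yl, morpholin-4-yl or dimethylamino group on the same carbonyl carbon would help separate those two possibilities.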